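A few compounds are considered here, and "the series" means these few. Any claim that something is new, unique, unknown or untested is made for them only; others in the source may bear on it.

Compound 1 (`CN(c1ccccc1)c1cc(C(=O)Nc2ccccc2)ncn1`), compound 2 (`CCN(Cc1ccc(Cl)cc1)c1cc(C(=O)Nc2ccccc2)ncn1`) and compound 3 (`CN(Cc1ccc(F)cc1)c1cc(C(=O)Nc2ccccc2)ncn1`) share one core and have been tested in a physicochemical assay for solubility, using the shake flask method, measured as kinetic solubility, with a stated time of 2 h, at pH 7.4 (a lower number here means a less soluble compound, a higher number a more soluble compound), so far. Compound 1 gives < 5000 nM as a limit, not a number. Going by these compounds, compound 3 likewise gives < 5000 nM as a limit, not a number, so its exact place on the scale is unknown. Compound 2 gives 5000 nM as a true reading. Taken together, the set shows the limit of < 5000 nM in this assay, at which 2 of the 3 values shown sit, and offers little else to build on.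

Compound 4 (`CN(Cc1ccc(C(F)(F)F)cc1)c1cc(C(=O)Nc2ccccc2)ncn1`) has trifluoromethyl in place of fluoro on an aromatic carbon, para to a large group, and trifluoromethyl in place of fluoro on an aromatic carbon gives the full count of that swap. Among the measured compounds shown here, the one measured step that bears on it is a step that the two limits leave unreadable from compound 1 to compound 3 and it offers no size to carry over. For the measured compounds named here, no measured step shows this swap itself, in either direction. No change beyond the usual scatter is therefore expected, and the estimated step is a step that the limit leaves unreadable from compound 3 to compound 4 in this assay as things stand. A limit rather than a number is the likelier report here too. For compound 4 the estimate is 3000 nM with an expected range of 1000 nM to 6000 nM in this read-out.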

Compound 4, solubility: < 5000 nM
Compound 4: a limit, no number (the forecaster's own chance of this, stated with the estimate: 75%); the middle value is on the limit's open side.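

Compound 3 and compound 4 each give a limit, not a number, in this assay, so the step between them cannot be read. The compounds shown leave open the true readings of compound 3 and compound 4, and with them what trifluoromethyl in place of fluoro does, as most of the set sits at one boundary: the limit of < 5000 nM in this assay, at which 3 of the 4 values shown sit.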